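Swapping the benzyl substituent on a piperidine amine

The compounds below may be only part of what the source reports. "The series", "measured", "known", "first", "only" and "open" are said of these compounds alone.

Compound 1, `COc1ccc2nccc(C3CN(C4CCN(Cc5cc6ccccc6[nH]5)CC4)C(=O)O3)c2c1`: in an in vitro functional assay on RBL cells for antagonist activity at C-C chemokine receptor type 8 (Homo sapiens), read by FLIPR and calcium flux (a lower number here means a stronger inhibitor, a higher number a weaker inhibitor), compound 1 gives 25.1 nM.
Compound 2, `COc1ccc2nccc(C3CN(C4CCN(CCCc5ccccc5)CC4)C(=O)O3)c2c1`: in this assay compound 2 gives 251 nM.
Compound 3, `COc1ccc2nccc(C3CN(C4CCN(Cc5ccccc5Cl)CC4)C(=O)O3)c2c1`: in this assay compound 3 gives only a limit, < 50200 nM.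

Compound 3 therefore stands at a limit of this assay rather than at a number, as recorded by the limit of < 50200 nM in this assay, at which 1 of the 3 values shown sits. The steps a step that the limit leaves unreadable from compound 1 to compound 3 and a step that the limit leaves unreadable from compound 2 to compound 3 are for that reason unreadable. Among the compounds with values here, the only readable step among the three is a 10-fold higher number from compound 1 to compound 2 (1.00 log units; beyond the scatter), which shows that the group on the saturated chain carbon bound to the ring amine nitrogen moves the value by a modest amount.

Compound 4, `COc1ccc(CN2CCC(N3CC(c4ccnc5ccc(OC)cc45)OC3=O)CC2)cc1`, differs from compound 3 by 4-methoxyphenyl in place of 2-chlorophenyl on a saturated chain carbon bound to an amine nitrogen in a ring. Within the data shown here, no measured step covers this exchange directly, and the limit of compound 3 gives no anchor for its size. Guided only by the range spanned by compound 1 and compound 2, compound 4 is expected to land at about 600 nM, between 100 nM and 6000 nM. The step that the limit leaves unreadable from compound 3 to compound 4 is thus an estimate that cannot be sized against the limit of compound 3.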

Compound 4, half-maximal inhibitory concentration: 1260 nM
Beside the measured number, compound 4's estimate is 2.1-fold (0.32 log units) below it; the measured number falls inside the stated range.
By their numbers in this assay, from the lowest: compound 1; then compound 2; then compound 4.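

Compound 4 gives this position a third readable value, and the first from a substituted benzyl group on a saturated chain carbon bound to an amine nitrogen in a ring. In this assay, 4-methoxyphenyl in place of phenethyl gives a 5.0-fold higher number from compound 2 to compound 4 (0.70 log units; beyond the scatter), and 4-methoxyphenyl in place of 1H-indol-2-yl gives a 50-fold higher number from compound 1 to compound 4 (1.70 log units; beyond the scatter), so among these three readable compounds the 1H-indol-2-yl compound has the lowest number and the 4-methoxyphenyl compound the highest. Compound 3 stands at a limit, so every step to or from it remains unreadable, including the one to compound 4: the limit of < 50200 nM in this assay, at which 1 of the 4 values shown sits.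

The compounds shown leave open whether the value of compound 4 follows from the methoxy group or from its place on the ring, which a 4-chlorophenyl or 2-methoxyphenyl group would help to separate. On these data alone, how an amine or a carboxylic acid on that phenyl ring would read also remains open.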